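The source may report more compounds than this note shows. Statements on the series, on what has been measured and on what is new or still open speak of the compounds shown alone.

Measured so far:
compound 1, `CCN(CC)c1ccc(C(=O)Nc2ccc(Oc3ncnc4ccsc34)cc2)cc1`, with 63.8% in a functional assay on A549 cells (Homo sapiens) for inhibition, read by MTT assay, with a stated time of 72 h, tested at 20 uM; on this read-out lower numbers stand for less inhibition and higher numbers for more inhibition at the one concentration tested (going by the name of the read-out);
compound 2, `CN(c1ccc(Oc2ncnc3ccsc23)cc1)c1nccc(N2CCCC2)n1`, with 63.9% in this assay.

Both compounds were tested at a single concentration, and the read-out tells how strongly the cells were held back at that concentration. Compound 2 has the higher of the two numbers, but its gap to compound 1 is within the scatter of repeated measurements, so the two cannot be told apart on these data. Among the measured compounds shown here, no step between two measured compounds that differ in one place is available.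

Compound 3, `CN(c1ccc(Oc2ncnc3ccsc23)cc1)c1nccc(N2CCCCC2)n1`, has not yet been measured. It differs from compound 2 in one place: piperidin-1-yl in place of pyrrolidin-1-yl on an aromatic carbon. For the measured compounds named here, with no comparable step among the measured compounds, the step from compound 2 to compound 3 in this assay is expected to be none beyond the scatter, in either direction. Compound 3 is therefore expected to give 62%, with a range from 45% to 78%, which corresponds to an expected step of a number 1.9 percentage points lower from compound 2 to compound 3 (within the scatter).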

Compound 3, a percentage reported as inhibition, at one concentration (the size of the read-out at that concentration, not a potency): 65.7%
Compound 3: the middle estimate sits 3.7 percentage points below what was measured; the measured number falls inside the stated range.
By their numbers in this assay, from the lowest: compounds 1, 2 and 3 (each within the scatter of the next).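

In this assay, among the compounds shown here, the exchange of pyrrolidin-1-yl for piperidin-1-yl on this aromatic carbon provides the first comparison of two compounds that differ in one place, and it comes out as a number 1.8 percentage points higher from compound 2 to compound 3 (within the scatter). For this one position, the five-membered and six-membered rings therefore cannot be told apart by this read-out at the one concentration tested. Nothing available here explains why the two rings give such similar readings.

Going by these compounds, what remains open is whether this position responds to groups of another kind, such as morpholine, an open-chain dimethylamino group or a carboxylic acid in place of the ring. A reading at one concentration is also not a potency, so compound 2 and compound 3 could still differ across a range of concentrations.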